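Swapping the sulfonyl group: cyclobutyl to dimethylamino

The source may report more compounds than this note shows. Statements on the series, on what has been measured and on what is new or still open speak of the compounds shown alone.

Of the compounds shown here, three sharing one core have been tested in an ADME assay on microsomes from liver (Mus musculus) for metabolic stability, read by LC-MS, using NADPH, with a stated time of 60 min, tested at 10 uM; on this read-out lower numbers stand for a shorter-lived compound and higher numbers for a longer-lived compound. Compound 2 `O=C([C@@H]1CCCN(S(=O)(=O)c2ccc(S(=O)(=O)C3CCC3)cc2)C1)N1CCC(F)(F)CC1` gives 0.733 h, the highest of the three numbers. Compound 3 `CCN(CC)S(=O)(=O)c1ccc(S(=O)(=O)N2CCC[C@@H](C(=O)NC3COC3)C2)cc1`, which carries a diethylamino group on its sulfonyl sulfur and a different amide, gives 0.452 h, within the scatter of compound 2. Compound 1 `CCC(CC)S(=O)(=O)c1ccc(S(=O)(=O)N2CCC[C@@H](C(=O)N3CCC(F)(F)CC3)C2)cc1` gives 0.145 h, and the step of a 5.1-fold higher number from compound 1 to compound 2 (0.70 log units; beyond the scatter) lies beyond the scatter, so compound 2 is clearly longer-lived than compound 1.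

Compound 4 `CN(C)S(=O)(=O)c1ccc(S(=O)(=O)N2CCC[C@@H](C(=O)N3CCC(F)(F)CC3)C2)cc1` has not yet been measured. It differs from compound 2 in one place: dimethylamino in place of cyclobutyl on a sulfonyl sulfur. Among the measured compounds shown here, only one measured step touches this same position, the exchange of pentan-3-yl for cyclobutyl that gave a 5.1-fold higher number from compound 1 to compound 2 (0.70 log units; beyond the scatter); it shows the group on the sulfonyl sulfur can shift the half-life beyond the scatter. For the measured compounds named here, no measured pair isolates the move to a dialkylamino group, and compound 3, the only compound bearing such a group, sits within the scatter of compound 2. The expected step of a 1.2-fold higher number from compound 2 to compound 4 (0.09 log units; within the scatter) is therefore small, with no confident direction. Compound 4 is estimated at 0.9 h, with a likely range from 0.4 h to 2 h in this assay.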

Compound 4, half-life: 0.533 h
Compound 4: the middle estimate sits 1.7-fold (0.23 log units) above what was measured, and the stated range covers the measured number.
By their numbers in this assay, from the lowest: compound 1; then compounds 3, 4 and 2 (each within the scatter of the next).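

In this assay, among the compounds shown here, compounds 2 and 4 form the first pair in which a group with nitrogen, dimethylamino, can be compared at this position with the rest of the molecule unchanged, and the swap from cyclobutyl gives a 1.4-fold lower number from compound 2 to compound 4 (0.14 log units; within the scatter). The four-membered carbon ring can therefore give way to an open group carrying nitrogen with no change beyond the scatter, while the step from pentan-3-yl, a 3.7-fold higher number from compound 1 to compound 4 (0.57 log units; beyond the scatter), shows that compound 1 now stands clearly apart from both other compounds that differ from it only on this sulfonyl sulfur. Nothing available explains why pentan-3-yl stands apart from cyclobutyl and dimethylamino here.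

The compounds shown leave open whether this tolerance extends to other groups on the same sulfur, such as a pyrrolidine or morpholine ring joined through its nitrogen, or a small carbon group such as isopropyl. They also leave open how diethylamino would compare with dimethylamino if it were paired with the amide of compound 4, since compound 3 differs in its amide as well.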